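Swapping bromo for fluoro on a fused bicyclic amide

This account rests on a few compounds, and the source may have more. Where it says the series, first, only, none or still open, it means among the compounds named here.

Measured so far:
- compound 1, `NC(=O)/C=C1\CCc2c(F)cccc21`, 40%
- compound 2, `CNC(=O)/C=C1\CCc2ccc(Br)cc21`, 44%

Of the compounds shown here, two sharing the same core have been tested in a functional assay on the whole organism with Rattus norvegicus as the target, at a dose of 20 mg/kg by the oral route; a lower number here means less inhibition, a higher number more inhibition at the dose given (going by the name of the read-out). Compound 1 gives 40%, and compound 2 gives 44%. Compound 2 holds the higher of the two numbers, but the gap to compound 1 lies within the usual scatter of this kind of measurement, so the two cannot be told apart.

The next compound is compound 3, `CNC(=O)/C=C1\CCc2ccc(F)cc21`. It keeps everything of compound 2 except at one spot: fluoro in place of bromo on an aromatic carbon.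

For the measured compounds named here, no step between two measured compounds that differ only at this spot is available, so there is nothing to lean on beyond the two numbers already seen. Both measured compounds sit in the same range, and the change itself is small in size. The expectation for compound 3 is therefore a step of a number 4 percentage points lower from compound 2 to compound 3 (within the scatter), that is, no movement beyond the scatter. Compound 3 is estimated at 40%, with a range from 25% to 55%.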

Compound 3, a percentage reported as inhibition, in the whole organism at one dose (the size of the read-out at that dose, not a potency): 45%
Compound 3: the middle estimate sits 5 percentage points below what was measured; measured number inside the range.
By their numbers in this assay, from the lowest: compounds 1, 2 and 3 (each within the scatter of the next).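

In this assay, for the compounds shown here, fluoro in place of bromo on an aromatic carbon gives a number 1 percentage points higher from compound 2 to compound 3 (within the scatter), the first direct comparison at this position of the shared core. At this spot on the six-membered aromatic ring, one heavy atom of bromine can therefore be exchanged for one of fluorine with no movement beyond the usual scatter, although this single pair, tested at one dose, speaks only for this one spot and this one swap. Nothing measured here offers an explanation for this outcome.

Going by these compounds alone, whether a group of a different kind at this same spot, such as an amine, a methoxy group or a carboxylic acid, would move the number beyond the scatter stays open, since fluoro and bromo are the only groups compared here. Compound 1 differs from compound 3 in more than one place, so no single change can be read from that pair, and the contribution of the amide end of the molecule remains an open question as well.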